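Swapping a tolyl for a tosylamide methyl on the triazole

The source may hold more compounds than are shown below. What is called first, only, known or untested is meant among the compounds shown, and "the series" means these compounds.

Compounds measured so far:
- compound 1 `CCCCc1cn(C[C@H](O)[C@H]2OC(=O)C(OCc3ccccc3)=C2OCc2ccccc2)nn1`, 32800 nM
- compound 2 `O=C1O[C@H]([C@@H](O)Cn2cc(CNS(=O)(=O)c3ccc(Cl)cc3)nn2)C(OCc2ccccc2)=C1OCc1ccccc1`, 7510 nM
- compound 3 `Cc1ccc(-c2cn(C[C@H](O)[C@H]3OC(=O)C(OCc4ccccc4)=C3OCc3ccccc3)nn2)cc1`, 8770 nM

All three share the same core and differ only in the group on the triazole ring. In a functional assay on HepG2 cells (Homo sapiens) for antiproliferative activity, read by MTT assay, with a stated time of 72 h (a higher number here means a weaker inhibitor, a lower number a stronger inhibitor), compound 3 gives 8770 nM, the second highest of the three numbers; it sits close to compound 2 and well apart from compound 1, as the steps of a 1.2-fold higher number from compound 2 to compound 3 (0.07 log units; within the scatter) and a 3.7-fold lower number from compound 1 to compound 3 (0.57 log units; beyond the scatter) show.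

Compound 4 `Cc1ccc(S(=O)(=O)NCc2cn(C[C@H](O)[C@H]3OC(=O)C(OCc4ccccc4)=C3OCc3ccccc3)nn2)cc1` carries the change ((((4-methylphenyl)sulfonyl)amino)methyl in place of 4-methylphenyl on an aromatic carbon). The nearest guide is compound 2, whose group differs from that of compound 4 only in the chlorine on the outer ring being replaced by methyl, and the step of a 1.2-fold higher number from compound 2 to compound 3 (0.07 log units; within the scatter) between compound 2 and compound 3 lies within the scatter. The step of a 4.4-fold lower number from compound 1 to compound 2 (0.64 log units; beyond the scatter) shows that this kind of sulfonamide arm gives a modest but real gain over a plain chain.

For compound 4 the step of a 1.2-fold lower number from compound 3 to compound 4 (0.07 log units; within the scatter) is expected, that is, no change beyond the scatter. Compound 4 is therefore estimated at 7500 nM, with a range from 3500 nM to 16000 nM.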

Compound 4, half-maximal inhibitory concentration: 24900 nM
Compound 4: the middle estimate sits 3.3-fold (0.52 log units) below what was measured; measured number above the stated range.
By their numbers in this assay, from the lowest: compounds 2 and 3 (each within the scatter of the next); then compounds 4 and 1 (each within the scatter of the next).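

The sulfonamide arm does not bring a gain by itself: exchanging the chloro on its outer ring for methyl costs activity (a 3.3-fold higher number from compound 2 to compound 4 (0.52 log units; beyond the scatter)), so the group on that ring matters more than compound 2 alone suggested. With methyl there, the arm does no better than the butyl of compound 1 (a 1.3-fold lower number from compound 1 to compound 4 (0.12 log units; within the scatter)), and it falls behind the 4-methylphenyl attached directly to the triazole (a 2.8-fold higher number from compound 3 to compound 4 (0.45 log units; beyond the scatter)). No measurement is available that explains the effect of this exchange on the outer ring.

Still open, as far as these compounds go, is how other groups on that ring, such as fluoro or methoxy, would compare with chloro and methyl. A 4-chlorophenyl attached directly to the triazole would show whether chloro has a similar effect without the sulfonamide arm.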